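Pyrazin-2-yl in Place of Triazole on the Aryl Tail

A few compounds are considered here, and "the series" means these few. Any claim that something is new, unique, unknown or untested is made for them only; others in the source may bear on it.

Going by the values given here, compound 3 `CCC(C)(C)Cc1c[nH]c(CCc2ccc(-n3ccnn3)cc2)n1` gives 641 nM in a functional assay on HEK293 cells for agonist activity at Bombesin receptor subtype-3 (Homo sapiens), read by luminescence and calcium flux, with a stated time of 10 min (on this read-out higher numbers stand for an effect only at larger amounts of compound and lower numbers for an effect already at smaller amounts), the highest number among the three compounds measured so far. Compound 2 `CCC(C)(C)Cc1c[nH]c(CCc2ccc(-n3ncnn3)cc2)n1` gives 422 nM and compound 1 `CCC(C)(C)Cc1c[nH]c(CCc2ccc(-n3cccn3)cc2)n1` gives 135 nM; the steps of a 4.7-fold higher number from compound 1 to compound 3 (0.68 log units; beyond the scatter) and a 3.1-fold higher number from compound 1 to compound 2 (0.49 log units; beyond the scatter) both lie beyond the scatter, whereas a 1.5-fold higher number from compound 2 to compound 3 (0.18 log units; within the scatter) does not. Compound 4 `CCC(C)(C)Cc1c[nH]c(CCc2ccc(-c3cnccn3)cc2)n1` carries the change (pyrazin-2-yl in place of 1H-1,2,3-triazol-1-yl on an aromatic carbon). Among the compounds with values here, none of the measured steps exchanges a five-membered ring for a six-membered one, so they bear on this step only loosely: the three five-membered rings span a modest range, and the new ring is a different kind of change. Compound 4 is therefore expected to show a step of a 1.3-fold lower number from compound 3 to compound 4 (0.11 log units; within the scatter) staying within the scatter, with an estimated value of 500 nM and a range from 150 nM to 1600 nM.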

Compound 4, half-maximal effective concentration: 431 nM
For compound 4 the middle estimate is 1.2-fold (0.06 log units) above the measured one; low and high end bracket the measured number.
By their numbers in this assay, from the lowest: compound 1; then compounds 2, 4 and 3 (each within the scatter of the next).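

At this position, on an aromatic carbon para to a large group, a six-membered aromatic ring stands level with two of the five-membered ones: the data show (a 1.5-fold lower number from compound 3 to compound 4 (0.17 log units; within the scatter)) and (a 1.0-fold higher number from compound 2 to compound 4 (0.01 log units; within the scatter)). Only 1H-pyrazol-1-yl stays apart (a 3.2-fold higher number from compound 1 to compound 4 (0.50 log units; beyond the scatter)), so ring size alone does not separate compound 1 from compounds 2, 3 and 4. The compounds shown offer no evidence on what sets compound 1 apart. From the compounds shown here alone, whether a morpholine or a carboxylic acid at this position would match compound 1 remains open.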